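The source may report more compounds than this note shows. Statements on the series, on what has been measured and on what is new or still open speak of the compounds shown alone.

Compound 1 `O=C1/C(=C\c2ccccc2)c2c(ncn2COCc2ccccc2)CCN1Cc1ccccc1` gives 20000 nM
Compound 2 `O=C1/C(=C\c2ccccc2)c2c(ncn2COCc2ccccc2)CCN1Cc1ccc(Cl)cc1` gives 10500 nM

In a functional assay on HCT-116 cells (Homo sapiens) for inhibition, read by MTT assay, with a stated time of 72 h (on this read-out higher numbers stand for weaker inhibition and lower numbers for stronger inhibition), compound 2 gives 10500 nM and sits level with compound 1 within the scatter. Compound 3 `O=C1/C(=C\c2ccccc2)c2c(ncn2COCc2ccccc2)CCN1Cc1ccc2ccccc2c1` differs from compound 2 by naphthalen-2-yl in place of 4-chlorophenyl on a saturated chain carbon bound to an amide-type nitrogen in a ring. Among the measured compounds shown here, the only measured change on this group is a 1.9-fold lower number from compound 1 to compound 2 (0.28 log units; within the scatter) and it shows no clear trend, so no shift beyond the scatter is expected in this assay here. The expected step is a 1.1-fold lower number from compound 2 to compound 3 (0.02 log units; within the scatter) and remains a rough estimate. For compound 3 the estimate is 10000 nM (expected range 4000 nM to 25000 nM).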

Compound 3, half-maximal inhibitory concentration: 19400 nM
The estimate for compound 3 lay 1.9-fold (0.29 log units) below the measured number; measured number inside the range.
By their numbers in this assay, from the lowest: compounds 2, 3 and 1 (each within the scatter of the next).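

Replacing 4-chlorophenyl with naphthalen-2-yl gives a 1.8-fold higher number from compound 2 to compound 3 (0.27 log units; within the scatter) and replacing phenyl with naphthalen-2-yl gives a 1.0-fold lower number from compound 1 to compound 3 (0.01 log units; within the scatter) in this assay on this read-out. At this place, on a saturated chain carbon bound to an amide-type nitrogen in a ring, a second aromatic ring therefore moves the number no further than the scatter, just as the chloro did. Nothing available explains this result.

All three compounds carry only aromatic carbon rings here, with or without chloro. As far as these compounds go, whether an amine or a carboxylic acid at this place would shift the number beyond the scatter remains open.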